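The source may report more compounds than this note shows. Statements on the series, on what has been measured and on what is new or still open speak of the compounds shown alone.

Compound 2 `COc1ccc(Sc2nc3cc(N)cc(N)c3nc2-c2ccccc2)cc1` is one of two compounds examined in a functional assay on NCI-H460 cells (Homo sapiens) for inhibition, read by sulforhodamine B assay, with a stated time of 48 h; a higher number here means that more compound is tolerated, a lower number that less compound is tolerated. In this assay compound 2 gives < 100000 nM, and this figure is a limit of the assay rather than a measured number. Compound 1 `Nc1cc(N)c2nc(-c3ccccc3)c(NCc3ccc(Cl)c(Cl)c3)nc2c1` was run in the same way; in this assay compound 1 gives < 100000 nM, which is likewise a limit. Among the compounds with values here, both results therefore rest on (the limit of < 100000 nM in this assay, at which 2 of the 2 values shown sit), so no step between the two measured compounds can be counted, and nothing here tells how far either compound lies from that boundary.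

Compound 3 `Nc1cc(N)c2nc(-c3ccccc3)c(Sc3ccc(F)cc3)nc2c1` differs from compound 2 by fluoro in place of methoxy on an aromatic carbon. Within the data shown here, since no measured step is available, compound 3 is expected to show no change beyond the usual scatter, with a step that the limit leaves unreadable from compound 2 to compound 3 anticipated. Compound 3 is accordingly estimated at 50000 nM, within a range of 10000 nM to 100000 nM.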

Compound 3, concentration lethal to 50% of the cells: < 100000 nM
Compound 3: a limit, no number; the forecaster's own chance of this, stated with the estimate: 60%; the middle value lies beyond the limit too.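

Within the data shown here, no step from compound 2 to compound 3 can be read, as each result is only a limit: the limit of < 100000 nM in this assay, at which 3 of the 3 values shown sit. The compounds shown leave open how far each lies from that limit, and whether fluoro in place of methoxy changes anything in this assay at all.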